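Oxygen Enters the Side Chain of Compound 1

A few compounds are considered here, and "the series" means these few. Any claim that something is new, unique, unknown or untested is made for them only; others in the source may bear on it.

Compound 1 `CCCCC1([C@H](O)/C=C/[C@H]2COC(=O)N2CCSc2nc(C(=O)O)cs2)CCC1`: 220 nM
Compound 2 `CC(C)(C)CCC1([C@H](O)/C=C/[C@H]2COC(=O)N2CCSc2nc(C(=O)O)cs2)CCC1`: 149 nM
Compound 3 `CC#CCC1([C@H](O)/C=C/[C@H]2COC(=O)N2CCSc2nc(C(=O)O)cs2)CCC1`: 89 nM

The three measured compounds share one core and differ only in the side chain attached to the saturated ring. In an assay on isolated protein for binding affinity to prostaglandin E2 receptor EP1 subtype (Homo sapiens) (on this read-out higher numbers stand for weaker inhibition and lower numbers for stronger inhibition), compound 1 gives 220 nM, the highest of the three numbers. The nearest number comes from a 1.5-fold lower number from compound 1 to compound 2 (0.17 log units; within the scatter), the furthest from a 2.5-fold lower number from compound 1 to compound 3 (0.39 log units; beyond the scatter). The remaining measured step is a 1.7-fold lower number from compound 2 to compound 3 (0.22 log units; within the scatter).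

Compound 4 `CCOCCC1([C@H](O)/C=C/[C@H]2COC(=O)N2CCSc2nc(C(=O)O)cs2)CCC1` has not yet been measured. Set against compound 1 it shows this difference: ethoxy in place of ethyl on a saturated chain carbon, two bonds along the chain from a saturated ring carbon

Going by the values given here, only one measured step sits at the same place on the chain, namely a 1.5-fold lower number from compound 1 to compound 2 (0.17 log units; within the scatter), and that step stayed within the scatter. The other two steps act at a different position, and none of the three brings an oxygen into the side chain, so there is no direct guide for an ethoxy group. On that basis the expectation for compound 4 is a step that stays within the scatter, a 1.1-fold lower number from compound 1 to compound 4 (0.04 log units; within the scatter). The estimate for compound 4 in this assay is 200 nM, expected to fall between 80 nM and 500 nM.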

Compound 4, inhibition constant: 8420 nM
Compound 4: middle estimate off by 42-fold (1.62 log units), on the low side, outside the stated range (above it).
By their numbers in this assay, from the lowest: compounds 3, 2 and 1 (each within the scatter of the next, the first and the last beyond it); then compound 4.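

The same place on the chain that barely responded to tert-butyl in place of ethyl turns out to be highly sensitive in this assay: ethoxy in place of ethyl gives a 38-fold higher number from compound 1 to compound 4 (1.58 log units; beyond the scatter). The other two side chains, which contain no oxygen, show the same gap, with a 57-fold higher number from compound 2 to compound 4 (1.75 log units; beyond the scatter) and a 95-fold higher number from compound 3 to compound 4 (1.98 log units; beyond the scatter), so among these four compounds the one whose side chain holds an oxygen, counted as a hydrogen-bond acceptor, stands alone at the weak end. This is a link seen in a single compound, and nothing measured here explains why the number rises so far.

From the compounds shown here alone, it remains open whether the oxygen itself matters or only the exact shape of the chain, and a straight pentyl chain at this position would help separate the two, since it keeps a similar chain with carbon throughout. Going by these compounds, it is equally open whether any oxygen on this chain gives the same result, as a methoxy group or a hydroxyl group might, or whether an amine in the same place would behave like the ethoxy group.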